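From pyridin-3-yl to pyridin-4-yl: compound 2 to compound 4

A few compounds are considered here, and "the series" means these few. Any claim that something is new, unique, unknown or untested is made for them only; others in the source may bear on it.

compound 1 `CN1C/C(=C\c2cccnc2)C(=O)/C(=C/c2ccccc2C(F)(F)F)C1` 2550 nM
compound 2 `CN1C/C(=C\c2ccc(C(F)(F)F)cc2)C(=O)/C(=C/c2cccnc2)C1` 4790 nM
compound 3 `CN1C/C(=C\c2ccc(C#N)cc2)C(=O)/C(=C/c2cccnc2)C1` 12700 nM

All three values come from a functional assay on HepG2 cells (Homo sapiens) for cytotoxicity, read by MTT assay, with a stated time of 24 h; on this read-out lower numbers stand for stronger inhibition and higher numbers for weaker inhibition. Compound 1 and compound 2 lie within the scatter of each other, while compound 3 stands apart, with a 2.7-fold higher number from compound 2 to compound 3 (0.42 log units; beyond the scatter). The next case is compound 4 `CN1C/C(=C\c2ccncc2)C(=O)/C(=C/c2ccc(C(F)(F)F)cc2)C1`, which carries pyridin-4-yl in place of pyridin-3-yl on a double-bonded chain carbon bound to a double-bonded ring carbon. For the measured compounds named here, the one measured step, a 2.7-fold higher number from compound 2 to compound 3 (0.42 log units; beyond the scatter), is modest and swaps cyano for trifluoromethyl, so no measured step tests this change. No step beyond the scatter is expected, which leaves compound 2 at 4790 nM as the anchor. The expected change is a 1.0-fold higher number from compound 2 to compound 4 (0.02 log units; within the scatter). The estimate for compound 4 is 5000 nM, with an expected range of 2000 nM to 12000 nM.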

Compound 4, half-maximal inhibitory concentration: 8200 nM
The estimate for compound 4 lay 1.6-fold (0.21 log units) below the measured number, within the range that was stated.
By their numbers in this assay, from the lowest: compounds 1, 2, 4 and 3 (each within the scatter of the next, the first and the last beyond it).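

Pyridin-4-yl in place of pyridin-3-yl on a double-bonded chain carbon bound to a double-bonded ring carbon gives a 1.7-fold higher number from compound 2 to compound 4 (0.23 log units; within the scatter) in this assay. For the compounds shown here, this is the first direct reading of this change, and with trifluoromethyl retained on the other aryl ring, the two pyridine isomers cannot be separated at this place. No available evidence explains the result.

Still open, from the compounds shown here alone, is whether pyridin-2-yl or a carboxylic acid at this place would stay within the scatter of compound 2. Going by these compounds, it is also open whether the same swap behaves alike with the cyano group of compound 3.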